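This account rests on a few compounds, and the source may have more. Where it says the series, first, only, none or still open, it means among the compounds named here.

Compound 1 `CCCSc1nc2nc(C)cc(N3CC[C@@H](C)[C@@H](N(C)c4ncnc5[nH]ccc45)C3)n2n1` is measured in a functional assay on HGC-27 cells (Homo sapiens) for inhibition, read by MTT assay, with a stated time of 72 h; a higher number here means a weaker inhibitor, a lower number a stronger inhibitor; in that assay compound 1 gives 20900 nM.
Compound 2 `Cc1cc(N2CC[C@@H](C)[C@@H](N(C)c3ncnc4[nH]ccc34)C2)n2nc(SCc3cc(Cl)ccc3Cl)nc2n1` in this assay gives 19200 nM.
Compound 3 `Cc1cc(N2CC[C@@H](C)[C@@H](N(C)c3ncnc4[nH]ccc34)C2)n2nc(SCc3nc4ccccc4[nH]3)nc2n1` in this assay reaches only a limit of the assay, > 100000 nM.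

Compound 2 stands at one end of the two numbers shown, with compound 1 alongside it: the step of a 1.1-fold lower number from compound 1 to compound 2 (0.04 log units; within the scatter) lies within the scatter. Compound 3 sits at a limit (the limit of > 100000 nM in this assay, at which 1 of the 3 values shown sits), so the steps of an at least 4.7-fold higher number from compound 1 to compound 3 (0.67 log units; beyond the scatter) and an at least 5.2-fold higher number from compound 2 to compound 3 (0.71 log units; beyond the scatter) can only be read as at least modest.

Compound 4 `Cc1cc(N2CC[C@@H](C)[C@@H](N(C)c3ncnc4[nH]ccc34)C2)n2nc(SCc3ccc(F)c(Cl)c3)nc2n1` is not yet measured. It differs from compound 2 by 3-chloro-4-fluorophenyl in place of 2,5-dichlorophenyl on a saturated chain carbon bound to a sulfur. The measured steps at this place are of two kinds: an exchange of ethyl for 2,5-dichlorophenyl that changed nothing beyond the scatter, and an exchange for 1H-benzimidazol-2-yl that weakened inhibition at least modestly. The change to compound 4 keeps a halogenated phenyl ring and resembles the first kind, so compound 4 is expected to give a value close to that of compound 2, with the step of a 1.0-fold lower number from compound 2 to compound 4 (0.00 log units; within the scatter) expected to stay within the scatter. Compound 4 is therefore estimated at 19000 nM, between 8000 nM and 45000 nM.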

Compound 4, half-maximal inhibitory concentration: > 100000 nM
Compound 4: only a limit was reported (the forecaster's own chance of this, stated with the estimate: 10%); middle value at least 5.2-fold (0.72 log units) away from the limit.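

The exchange of 2,5-dichlorophenyl for 3-chloro-4-fluorophenyl on a saturated chain carbon bound to a sulfur keeps the count of heavy atoms and the carbon-only aromatic ring, yet it gives an at least 5.2-fold higher number from compound 2 to compound 4 (0.71 log units; beyond the scatter), so at this place the halogens on the phenyl ring decide the reading in this assay, not just the presence of such a ring. Measured against ethyl, the new group gives an at least 4.7-fold higher number from compound 1 to compound 4 (0.67 log units; beyond the scatter), whereas 2,5-dichlorophenyl in place of ethyl stayed within the scatter. Compound 4 gives only a limit of the assay, > 100000 nM, and its step to compound 3 cannot be read, so the two cannot be ordered: the limit of > 100000 nM in this assay, at which 2 of the 4 values shown sit.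

The compounds shown leave open whether the fluorine or the different placing of the chlorine carries this step; the two change together here. Also open, going by these compounds, is how a plain benzyl group, or an amine or carboxylic acid on the chain, would read.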